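Replacing 1,3-thiazol-4-yl with quinolin-2-yl on a carbonyl carbon

The source may hold more compounds than are shown below. What is called first, only, known or untested is meant among the compounds shown, and "the series" means these compounds.

Compound 1 `COc1ccc(Cl)cc1C(=O)NCCC1CCN(S(=O)(=O)NC(=O)NC2CCCCC2)CC1`: 25%
Compound 2 `O=C(NC1CCCCC1)NS(=O)(=O)N1CCC(CCNC(=O)c2cscn2)CC1`: 23%

Both measured compounds were tested in a functional assay on the whole organism (blood) with Rattus norvegicus as the target, with stated times of 24 h and 1 h, at a dose of 5 mg/kg by the intraperitoneal route; a higher number here means a stronger effect of the compound at the dose given, a lower number a weaker effect. Compound 2 stands alongside compound 1 in this assay, the step of a number 2 percentage points lower from compound 1 to compound 2 (within the scatter) being within the scatter, so the two numbers cannot be told apart. That step is the only one measured, and it already concerns the group on the carbonyl carbon next to the amide-type nitrogen: one aromatic group was exchanged for another and the read-out did not move beyond the scatter.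

Compound 3 `O=C(NC1CCCCC1)NS(=O)(=O)N1CCC(CCNC(=O)c2ccc3ccccc3n2)CC1` differs from compound 2 in quinolin-2-yl in place of 1,3-thiazol-4-yl on a carbonyl carbon. This change falls at the same place as the measured step. With one exchange at that position having left the number unchanged, compound 3 is expected to show no step beyond the scatter, a number 1 percentage points higher from compound 2 to compound 3 (within the scatter). Compound 3 is therefore estimated at 24%, in a range from 10% to 38%.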

Compound 3, a percentage reported as activity, at one dose (the size of the read-out at that dose, not a potency): 11%
Estimate against measurement, compound 3: 13 percentage points above, and the stated range covers the measured number.
By their numbers in this assay, from the lowest: compound 3; then compounds 2 and 1 (each within the scatter of the next).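

The exchange at the carbonyl carbon is not always silent: in this assay, quinolin-2-yl gives a number 12 percentage points lower from compound 2 to compound 3 (beyond the scatter) and a number 14 percentage points lower from compound 1 to compound 3 (beyond the scatter), so this position can respond to the aromatic group it carries. Among these three compounds, quinolin-2-yl alone stands apart, while 1,3-thiazol-4-yl and 5-chloro-2-methoxyphenyl remain within the scatter of each other. Nothing available explains why the read-out falls with this group.

The compounds shown leave open whether the lower number goes with the second aromatic ring of quinolin-2-yl or with its placement of the ring nitrogen, a question that pyridin-2-yl or naphthalen-2-yl on the same carbonyl carbon would address. With a read-out at a single dose, they also leave open whether the gap would persist at other doses.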